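The compounds below may be only part of what the source reports. "The series", "measured", "known", "first", "only" and "open" are said of these compounds alone.

Measured compounds in an in vitro functional assay on HEK285-7 cells for antagonist activity at prostaglandin D2 receptor 2 (Homo sapiens), read by BRET and beta-arrestin recruitment; a lower number here means a smaller maximal response, a higher number a larger maximal response:
Compound 1 `O=C(O)Cc1sc(Cc2ccccc2)nc1-c1ccc(Cl)cc1` gives 50%.
Compound 2 `CCC(c1ccccc1)c1nc(-c2ccc(Cl)cc2)c(CC(=O)O)s1` gives 50%.
Compound 3 `O=C(O)Cc1sc(C(c2ccc(F)cc2)c2ccc(F)cc2)nc1-c1cc(F)cc(F)c1` gives 80%.

Compound 3 stands highest of the three in this assay; compound 1 and compound 2 both lie lower by more than the scatter. Within the data shown here, the only measured step, no change at the digits printed from compound 1 to compound 2 (within the scatter), concerns ethyl in place of hydrogen on a saturated chain carbon bound to two aromatic carbons and leaves the ring position altered here untouched. Compound 4 `O=C(O)Cc1sc(C(c2ccc(F)cc2)c2ccc(F)cc2)nc1-c1cn[nH]c1` differs from compound 3 by 1H-pyrazol-4-yl in place of 3,5-difluorophenyl on an aromatic carbon. Among the measured compounds shown here, no measured step covers a change at this aromatic carbon, so the direction is open and the estimate is uncertain. Compound 4 is expected to show a step of a number 20 percentage points lower from compound 3 to compound 4 (beyond the scatter). Compound 4 is estimated at 60%, with a range from 35% to 85%.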

Compound 4, largest response reached (reported as efficacy), in percent of the reference or control that the assay uses: 80%
The estimate for compound 4 lay 20 percentage points below the measured number, within the range that was stated.
By their numbers in this assay, from the lowest: compounds 1 and 2 (each within the scatter of the next); then compounds 3 and 4 (each within the scatter of the next).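

In this assay, putting 1H-pyrazol-4-yl in place of 3,5-difluorophenyl gives no change at the digits printed from compound 3 to compound 4 (within the scatter). Among these compounds, this is the first step read at this aromatic carbon, and it shows that the maximal response here does not depend on keeping a six-membered aromatic ring of carbon only: a five-membered aromatic ring with 2 hetero atoms serves equally. No measurement at hand accounts for this outcome.

The compounds shown leave open whether a pyridine ring or a primary amine on this carbon would leave the response unchanged. They also leave open whether 1H-pyrazol-4-yl would behave alike on the core of compound 1.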